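Swapping the hydrazone aryl group for a pyridine

The source may report more compounds than this note shows. Statements on the series, on what has been measured and on what is new or still open speak of the compounds shown alone.

In a functional assay on M14 cells (Homo sapiens) for inhibition, read by sulforhodamine B assay, with a stated time of 48 h (a lower number here means a stronger inhibitor of growth, a higher number a weaker inhibitor of growth), compound 2 `Cc1nn(-c2ccccc2)cc1/C=N/Nc1nc(Nc2ccccc2)nc(Nc2ccc(S(N)(=O)=O)cc2)n1` gives 2060 nM, which is the lowest of the two numbers seen so far; its nearest neighbour is compound 1 `NS(=O)(=O)c1ccc(Nc2nc(N/N=C/c3ccc(C(F)(F)F)cc3)nc(Nc3ccccc3)n2)cc1`, which in this assay gives 2510 nM. The step of a 1.2-fold lower number from compound 1 to compound 2 (0.09 log units; within the scatter) already concerns the same position as the change now in question, and it stayed within the scatter. Compound 3 `NS(=O)(=O)c1ccc(Nc2nc(N/N=C/c3ccccn3)nc(Nc3ccccc3)n2)cc1` differs from compound 2 only here: pyridin-2-yl in place of 3-methyl-1-phenyl-1H-pyrazol-4-yl on a carbon with a double bond to nitrogen. For the measured compounds named here, because the one measured step at this position, a 1.2-fold lower number from compound 1 to compound 2 (0.09 log units; within the scatter), produced no shift beyond the scatter, a change in this assay from compound 2 to compound 3 of no more than the scatter is expected, without a clear direction. The expected step is a 1.1-fold higher number from compound 2 to compound 3 (0.05 log units; within the scatter). For compound 3 the estimate in this assay is 2300 nM, with a range from 800 nM to 6500 nM.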

Compound 3, concentration for 50% growth inhibition: 850 nM
Estimate against measurement, compound 3: 2.7-fold (0.43 log units) above, within the range that was stated.
By their numbers in this assay, from the lowest: compound 3; then compounds 2 and 1 (each within the scatter of the next).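

The position turns out not to be indifferent: in this assay, pyridin-2-yl on the carbon with a double bond to nitrogen gives a 2.4-fold lower number from compound 2 to compound 3 (0.38 log units; beyond the scatter) and also a 3.0-fold lower number from compound 1 to compound 3 (0.47 log units; beyond the scatter), so both steps pass the scatter, whereas compound 1 and compound 2 stayed within it. The group that enters has 6 heavy atoms and one ring, while 3-methyl-1-phenyl-1H-pyrazol-4-yl has 12 heavy atoms and two rings. Nothing shown here accounts for the lower number of compound 3.

For the compounds shown here, with only three groups, the data cannot separate the effect of removing the second ring from that of the pyridine ring nitrogen or its place in the ring. Plain phenyl, pyridin-3-yl and pyridin-4-yl at this carbon would each help to separate these, and how they compare remains open.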